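The source may report more compounds than this note shows. Statements on the series, on what has been measured and on what is new or still open speak of the compounds shown alone.

Measured so far:
- compound 1 `O=C(Nc1cc(C(F)(F)F)cc(C(F)(F)F)c1)NN1CCOCC1`: 5 ug/mL
- compound 2 `O=C(NNC(=O)Nc1cc(C(F)(F)F)cc(C(F)(F)F)c1)Nc1cc(C(F)(F)F)cc(C(F)(F)F)c1`: < 0.5 ug/mL
- compound 3 `CCc1nc2ccccc2c(=O)n1NC(=O)Nc1cc(C(F)(F)F)cc(C(F)(F)F)c1`: 59 ug/mL

The three compounds share a bis(trifluoromethyl)phenyl urea and differ in what sits on the far nitrogen of the urea. In a physicochemical assay for solubility, at pH 7.4 (a lower number here means a less soluble compound, a higher number a more soluble compound), compound 1 gives 5 ug/mL, the lowest of the two numbers recorded. The nearest number is that of compound 3, which in this assay gives 59 ug/mL, a gap that lies beyond the scatter of the measurement. For compound 2 the result in this assay is only a limit, < 0.5 ug/mL, and the limit of < 0.5 ug/mL in this assay, at which 1 of the 3 values shown sits, marks it as such; no number is known for it.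

Compound 4 `O=C(Nc1cc(C(F)(F)F)cc(C(F)(F)F)c1)Nn1cnnc1` has not yet been measured. Against compound 1 the change is 4H-1,2,4-triazol-4-yl in place of morpholin-4-yl on an amide-type nitrogen. Both groups sit on the same amide-type nitrogen and neither carries a charge. Among the measured compounds shown here, with no measured pair that isolates such a swap, the step from compound 1 to compound 4 in this assay is expected to be modest, and its direction cannot be fixed from the numbers at hand. The estimate for compound 4 in this assay is 8 ug/mL, with a range of 2 ug/mL to 30 ug/mL, which would mean an expected step of a 1.6-fold higher number from compound 1 to compound 4 (0.20 log units; within the scatter).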

Compound 4, solubility: 53 ug/mL
For compound 4 the middle estimate is 6.6-fold (0.82 log units) below the measured one, and the stated range ends below it.
By their numbers in this assay, from the lowest: compound 1; then compounds 4 and 3 (each within the scatter of the next). At a limit, below all of these: compound 2.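

On the amide-type nitrogen whose other neighbour is the carbonyl carbon, 4H-1,2,4-triazol-4-yl in place of morpholin-4-yl gives in this assay an 11-fold higher number from compound 1 to compound 4 (1.03 log units; beyond the scatter), and this is the only pair shown that differs in one place, so the earlier compounds could not show how far this position alone can move the number. Neither the group that leaves nor the group that enters carries a net charge or a hydrogen-bond donor, so a step of this size at this position needs neither a charge nor a donor on the incoming group. Nothing measured in the series bears on why the number moves, so the step stands here as an observation only.

Among the compounds shown here, the one pair changes ring size, aromatic character and the set of hetero atoms together, and it leaves open which of these goes with the step. Also open, on these data alone, is how other groups on this nitrogen would read, such as piperidin-1-yl, which lacks the ring oxygen of morpholin-4-yl, or 1H-pyrazol-1-yl, a five-membered aromatic ring with fewer ring nitrogens than 4H-1,2,4-triazol-4-yl.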